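The compounds below may be only part of what the source reports. "The series", "measured", "known", "first", "only" and "open" are said of these compounds alone.

Measured so far in a functional assay on cells (Homo sapiens) for cytotoxicity; on this read-out lower numbers stand for higher toxicity in this test and higher numbers for lower toxicity in this test:

Compound 1 `O=C1N(CCCCCCOc2ccc(C(F)(F)F)cc2)CCN1c1ccncc1` gives a limit of the assay, > 25000 nM.
Compound 2 `O=C1N(CCCCCCOc2ccc(Cl)cc2)CCN1c1ccncc1` gives a limit of the assay, > 25000 nM.
Compound 3 `O=C1N(CCCCCCOc2ccc(C(F)(F)F)cc2)CCN1c1ccncn1` gives a limit of the assay, > 25000 nM.

None of the three values is a number; each is a limit, and all three sit at the same point, (the limit of > 25000 nM in this assay, at which 3 of the 3 values shown sit). Compound 2 differs from compound 1 by chloro in place of trifluoromethyl on an aromatic carbon; the step that the two limits leave unreadable from compound 1 to compound 2, so the size of that step cannot be read. Compound 3 differs from compound 1 in its core by pyrimidin-4-yl in place of pyridin-4-yl on an amide-type nitrogen in a ring; the step that the two limits leave unreadable from compound 1 to compound 3, again of unreadable size. Within the data shown here, no step is recorded between compound 2 and compound 3; their two values show only that both are limits at the same point.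

Compound 4 `O=C1N(CCCCCCOc2ccc(Cl)cc2)CCN1c1ccncn1` has not yet been measured in this assay. Among the measured compounds shown here, it differs from compound 3 by chloro in place of trifluoromethyl on an aromatic carbon, the same change as the one from compound 1 to compound 2, at a place described in the same words. For the measured compounds named here, the step from compound 3 to compound 4 is expected to be a step that the limit leaves unreadable from compound 3 to compound 4, a guess that rests on a step that the two limits leave unreadable from compound 1 to compound 2 and on (the limit of > 25000 nM in this assay, at which 3 of the 3 values shown sit), where every value so far has stopped. Compound 4 is therefore expected in this assay at about 40000 nM, with a range from 15000 nM to 120000 nM, and most likely only a limit will again be reported.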

Compound 4, half-maximal cytotoxic concentration: > 25000 nM
Compound 4: a limit, no number (the forecaster's own chance of this, stated with the estimate: 85%); the middle value does not contradict the limit.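

In this assay compound 4 gives > 25000 nM, a limit and not a number, so no step to compound 2 or compound 3 can be read: the limit of > 25000 nM in this assay, at which 4 of the 4 values shown sit.

The compounds shown leave open whether chloro in place of trifluoromethyl, or pyrimidin-4-yl in place of pyridin-4-yl, changes this read-out at all, with no number among compound 1, compound 2, compound 3 and compound 4.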